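From 3-chlorophenyl to 3-hydroxyphenyl in a growth assay

The source may hold more compounds than are shown below. What is called first, only, known or untested is meant among the compounds shown, and "the series" means these compounds.

Compound 1 `CC(C)CCn1cnc2c(NCc3cccc(Cl)c3)nc(N[C@H]3CC[C@H](N)CC3)nc21`: 1330 nM
Compound 2 `COc1cc(Nc2nc(N[C@H]3CC[C@H](N)CC3)nc3c2ncn3CCC(C)C)cc(OC)c1`: 140 nM
Compound 3 `CC(C)CCn1cnc2c(Nc3cccc(Cl)c3)nc(N[C@H]3CC[C@H](N)CC3)nc21`: 60 nM

All three values come from a functional assay on EOL1 cells (Homo sapiens) for inhibition, read by fluorescence, with a stated time of 72 h; on this read-out higher numbers stand for weaker inhibition of growth and lower numbers for stronger inhibition of growth. Compound 3 has the lowest number of the series, and the gaps to both other compounds lie beyond the scatter. The next compound, compound 4 `CC(C)CCn1cnc2c(Nc3cccc(O)c3)nc(N[C@H]3CC[C@H](N)CC3)nc21`, is still to be measured. It carries hydroxy in place of chloro on an aromatic carbon, meta to a large group, and the change is counted as hydroxy in place of chloro on an aromatic carbon.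

Among the measured compounds shown here, no measured step makes this exact exchange. For the measured compounds named here, the nearest precedent is a 2.3-fold lower number from compound 2 to compound 3 (0.37 log units; beyond the scatter), which exchanges 3,5-dimethoxyphenyl for 3-chlorophenyl and is modest. The steps of a 9.5-fold lower number from compound 1 to compound 2 (0.98 log units; beyond the scatter) and a 22-fold lower number from compound 1 to compound 3 (1.35 log units; beyond the scatter) are larger, but both replace 3-chlorobenzyl, a different kind of change, so they bear on compound 4 only loosely. Going by the values given here, with the phenyl group kept, the one measured exchange of its substituents moved the number only modestly. A modest step is therefore expected here too, most likely towards a higher number, although the data do not fix its direction firmly. The estimate for compound 4 is 100 nM, with an expected range from 30 nM to 330 nM. This estimate means an expected 1.7-fold higher number from compound 3 to compound 4 (0.22 log units; within the scatter).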

Compound 4, concentration for 50% growth inhibition: 60 nM
Beside the measured number, compound 4's estimate is 1.7-fold (0.22 log units) above it, and the stated range covers the measured number.
By their numbers in this assay, from the lowest: compounds 3 and 4 (each within the scatter of the next); then compound 2; then compound 1.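

In this assay, hydroxy in place of chloro on this aromatic carbon, meta to a large group, gives no change at the digits printed from compound 3 to compound 4 (within the scatter), so the read-out separates neither group here, although hydroxy, unlike chloro, is counted as a hydrogen-bond donor and acceptor. The earlier compounds showed only that 3-chlorophenyl stood apart from 3,5-dimethoxyphenyl and 3-chlorobenzyl; 3-hydroxyphenyl now shows the same gaps, with a 2.3-fold lower number from compound 2 to compound 4 (0.37 log units; beyond the scatter) and a 22-fold lower number from compound 1 to compound 4 (1.35 log units; beyond the scatter), so among these compounds the chloro itself is not what separates compound 3 from compound 2 and compound 1. Nothing available explains why the two groups read alike here.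

Going by these compounds, whether an amine or a carboxylic acid in place of chloro on this carbon would also leave the number undisturbed remains open, as does whether 3-methoxyphenyl would group with compound 3 and compound 4 or with compound 2. On these data alone, all the values shown come from this one growth read-out, so how hydroxy and chloro compare on any other read-out also remains open.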